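A few compounds are considered here, and "the series" means these few. Any claim that something is new, unique, unknown or untested is made for them only; others in the source may bear on it.

Measured in a functional assay on COR-L23 cells (Homo sapiens) for antiproliferative activity, read by CellTiter-Glo, with a stated time of 72 h; a higher number here means a weaker inhibitor, a lower number a stronger inhibitor:
- Compound 1 `Nc1ccc(CNC(=O)Nc2ccc(CN3C(=O)c4ccccc4C3=O)cc2)cn1`: 3.1 nM
- Compound 2 `O=C(Nc1ccc(CN2Cc3ccccc3C2=O)cc1)N1CCC(c2cccnc2)C1`: > 2500 nM; > 2500 nM (2 entries), a limit of the assay in both entries, not a number
- Compound 3 `C[C@H](NC(=O)c1ncccn1)c1ccc(NC(=O)N2CC(c3cccnc3)C2)cc1`: 130 nM

Compound 3 holds the higher of the two actual numbers, a gap beyond the scatter from compound 1. Compound 4 `C[C@H](NC(=O)[C@@H]1CCCN1C)c1ccc(NC(=O)N2CC(c3cccnc3)C2)cc1` carries 1-methylpyrrolidin-2-yl in place of pyrimidin-2-yl on a carbonyl carbon. Among the compounds with values here, no measured pair shows this change, so the data give no direct guide to its size or direction. A shift within the scatter is expected in this assay, with a weaker number slightly favoured, though a larger move either way remains possible. The expected change is a 1.5-fold higher number from compound 3 to compound 4 (0.19 log units; within the scatter). The estimate for compound 4 is 200 nM, with an expected range of 40 nM to 1000 nM.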

Compound 4, half-maximal inhibitory concentration: 38 nM
For compound 4 the middle estimate is 5.3-fold (0.72 log units) above the measured one; the whole stated range lies above it.
By their numbers in this assay, from the lowest: compound 1; then compound 4; then compound 3.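

In this assay, within the data shown here, 1-methylpyrrolidin-2-yl in place of pyrimidin-2-yl on a carbonyl carbon gives a 3.4-fold lower number from compound 3 to compound 4 (0.53 log units; beyond the scatter) and provides the first reading at this position. The six-membered aromatic ring is therefore not required here, and a five-membered non-aromatic ring with a defined stereocentre is accepted. Nothing measured here accounts for the step.

A single pair leaves open whether the ring, its methyl or its stereocentre matters. The unmethylated pyrrolidin-2-yl, the opposite stereoisomer and an open-chain amine such as dimethylaminomethyl would separate these.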